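The compounds below may be only part of what the source reports. "The series", "measured", "known", "first", "only" and "open" are said of these compounds alone.

Of the compounds shown here, two have been measured in a functional assay with sodium channel protein type 2 subunit alpha (Rattus norvegicus) as the target; a higher number here means a weaker inhibitor, a lower number a stronger inhibitor. Compound 1 `CCCCOc1ccc(NC(=N)Nc2ccc(OCCCC)cc2)cc1` gives 190 nM in this assay. Compound 2 `CCCCc1ccc(NC(=N)Nc2ccc(OCc3ccccc3)cc2)cc1` gives 140 nM in this assay. The numbers of compound 1 and compound 2 lie within the usual scatter of repeated measurements of each other, so on these data neither can be called the stronger inhibitor. Within the data shown here, no measured pair differs in only one place, so no step size has yet been observed.

Compound 3 `CCCCOc1ccc(NC(=N)Nc2ccc(CCCCO)cc2)cc1` has not been measured. It differs from compound 1 in one place: 4-hydroxybutyl in place of butoxy on an aromatic carbon. The same atoms are present in both, joined differently. Among the measured compounds shown here, no measured pair shows what such a change does in this assay, so any expectation rests on the structural change alone and remains uncertain. A step toward a higher number, meaning weaker inhibition, seems somewhat more likely than none, but a step within the scatter cannot be ruled out. Compound 3 is therefore expected to give about 400 nM, with a range from 130 nM to 1200 nM. This estimate corresponds to an expected step of a 2.1-fold higher number from compound 1 to compound 3 (0.32 log units; beyond the scatter).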

Compound 3, half-maximal inhibitory concentration in the sodium channel protein type 2 subunit alpha assay: 1780 nM
Beside the measured number, compound 3's estimate is 4.5-fold (0.65 log units) below it; the whole stated range lies below it.
By their numbers in the sodium channel protein type 2 subunit alpha assay, from the lowest: compounds 2 and 1 (each within the scatter of the next); then compound 3.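

Turning butoxy into 4-hydroxybutyl keeps the same atoms but joins them differently, and in the sodium channel protein type 2 subunit alpha assay it produces a 9.4-fold higher number from compound 1 to compound 3 (0.97 log units; beyond the scatter), the first step in this series that lies beyond the scatter. This shows that, on an aromatic carbon para to a large group, inhibition depends on how these atoms are arranged and not only on which atoms are present. In a physicochemical assay for lipophilicity, measured as octanol-water partition, at pH 7.4 (a higher number here means a more lipophilic compound, a lower number a more polar compound), compound 1 gives 3.52 and compound 3 gives 1.72. The change also adds a hydrogen-bond donor, and the weaker inhibition may be linked to a marked fall in lipophilicity, although a single pair cannot separate these two differences or prove either as the cause: the measured distribution coefficient of compound 1, 3.52, and of compound 3, 1.72, a number 1.80 log units lower (beyond the scatter).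

The compounds shown leave open whether the free hydroxyl itself is the decisive feature or whether any oxygen at the end of the chain would have the same effect, a question that a 4-methoxybutyl group at this position could address. They also do not show whether a shorter chain such as 2-hydroxyethyl, or a carboxylic acid at the end of the chain, would change inhibition further.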